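Methyl on the fused ring of compound 2

The compounds below may be only part of what the source reports. "The series", "measured", "known", "first", "only" and "open" are said of these compounds alone.

Compound 2 `Cc1[nH]n(-c2nc3ccccc3[nH]2)c(=O)c1Cc1ccccc1Cl` is one of two measured members of the shared core. In an assay on isolated protein for inhibition of alpha-ketoglutarate-dependent dioxygenase alkB homolog 3 (Homo sapiens), read by polymerase chain reaction, with a stated time of 1 h (on this read-out lower numbers stand for stronger inhibition and higher numbers for weaker inhibition), compound 2 gives only a limit of the assay, > 10000 nM. Compound 1 `COc1ccc(Cc2c(C)[nH]n(-c3nc4ccccc4[nH]3)c2=O)cc1` gives 630 nM in this assay, and the step of an at least 15-fold higher number from compound 1 to compound 2 (1.20 log units; beyond the scatter) is the only measured one; its size rests on (the limit of > 10000 nM in this assay, at which 1 of the 2 values shown sits). Compound 3 `Cc1ccc2[nH]c(-n3[nH]c(C)c(Cc4ccccc4Cl)c3=O)nc2c1` differs from compound 2 by methyl in place of hydrogen on an aromatic carbon. Among the compounds with values here, no measured step touches this position: the step from compound 1 to compound 2 concerns the group on the saturated chain carbon, which compound 3 keeps unchanged. The step from compound 2 to compound 3 is therefore expected to stay within the scatter, with no direction, as a step that the limit leaves unreadable from compound 2 to compound 3. Compound 3 is expected to give about 15000 nM in this assay, between 5000 nM and 50000 nM, most likely again reported only as a limit.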

Compound 3, half-maximal inhibitory concentration: 910 nM
The estimate for compound 3 lay 16-fold (1.22 log units) above the measured number, outside the stated range (below it).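

Methyl in place of hydrogen on this aromatic carbon, with the 2-chlorophenyl group kept, gives in this assay an at least 10-fold lower number from compound 2 to compound 3 (1.04 log units; beyond the scatter). Within the data shown here, the earlier compounds varied only the group on the saturated chain carbon, so this is the first sign that the fused ring also responds to a change, and compound 3 gives 910 nM, a measured number for a 2-chlorophenyl member of the series. Going by these compounds, the true size of the step stays unknown because compound 2 stands only as a limit of the assay: the limit of > 10000 nM in this assay, at which 1 of the 3 values shown sits.

On these data alone, it remains open whether methyl is special at this carbon or whether ethyl, methoxy or chlorine would serve as well. Also open, as far as these compounds go, is whether methyl would act the same with the 4-methoxyphenyl group of compound 1, since compound 1 and compound 3 differ in two places.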